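This account rests on a few compounds, and the source may have more. Where it says the series, first, only, none or still open, it means among the compounds named here.

Compound 1 `COc1ccc(Nc2ncc3c(n2)N(C2CCCC2)CC(=O)N3C)cc1` is tested in a functional assay on HCT-116 cells (Homo sapiens) for inhibition, read by MTT assay, with a stated time of 48 h (on this read-out lower numbers stand for stronger inhibition and higher numbers for weaker inhibition), where compound 1 gives 12300 nM, the highest of the three numbers recorded. Compound 2 `CCN1C(=O)CN(C2CCCC2)c2nc(Nc3ccc(OC)cc3)ncc21` gives 11000 nM in this assay, and compound 3 `CC1CCN(c2ccc(Nc3ncc4c(n3)N(C3CCCC3)CC(=O)N4)cc2)CC1` gives 8430 nM; both sit within the scatter of compound 1. Among the measured compounds shown here, the only single-point step among the measured compounds is a 1.1-fold lower number from compound 1 to compound 2 (0.05 log units; within the scatter), which concerns the amide-type nitrogen in the core and not the aryl substituent. Compound 4 `CN1C(=O)CN(C2CCCC2)c2nc(Nc3ccc(N4CCCCC4)cc3)ncc21` differs from compound 1 by piperidin-1-yl in place of methoxy on an aromatic carbon. For the measured compounds named here, no measured step bears directly on this change; compound 3, which also carries a ring nitrogen on the aromatic ring, differs from compound 1 in more than one place, and its value lies within the scatter of compound 1. The expectation is therefore a step of a 1.2-fold lower number from compound 1 to compound 4 (0.09 log units; within the scatter), that is none beyond the scatter. Compound 4 is expected to give about 10000 nM in this assay, within a range from 4000 nM to 25000 nM.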

Compound 4, half-maximal inhibitory concentration: 6100 nM
Compound 4: the middle estimate sits 1.6-fold (0.21 log units) above what was measured, and the stated range covers the measured number.
By their numbers in this assay, from the lowest: compounds 4, 3, 2 and 1 (each within the scatter of the next).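

At this position, on an aromatic carbon para to a large group, the change in this assay from methoxy to piperidin-1-yl gives a 2.0-fold lower number from compound 1 to compound 4 (0.30 log units; within the scatter). Among the compounds shown here, this is the first direct reading of a substituent change on this aromatic ring, as the earlier single-point step concerned only the amide-type nitrogen, and it shows that a group with a ring and more heavy atoms can replace methoxy here without a step beyond the scatter. Nothing given here explains the result.

The compounds shown leave open whether morpholin-4-yl, a carboxylic acid or a longer chain on this aromatic carbon would give a step beyond the scatter. They also leave open whether piperidin-1-yl would give a similar step with ethyl on the amide-type nitrogen of the shared core.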